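Methyl scan on a shared core: working notes

This account rests on a few compounds, and the source may have more. Where it says the series, first, only, none or still open, it means among the compounds named here.

Measured compounds:
compound 1, `CN1C(=O)[C@H](NC(=O)c2n[nH]c(Cc3ccccc3)n2)COc2ncccc21`: in a functional assay on HT-29 cells (Homo sapiens) for inhibition, read by luminescence and CellTiter-Glo, with a stated time of 10 h (on this read-out lower numbers stand for an effect already at smaller amounts and higher numbers for an effect only at larger amounts of compound), compound 1 gives > 10000 nM, which is a limit of the assay and not a number.
compound 2, `Cc1cnc2c(c1)N(C)C(=O)[C@H](NC(=O)c1n[nH]c(Cc3ccccc3)n1)CO2`: in this assay compound 2 gives > 10000 nM, again a limit of the assay.
compound 3, `CN1C(=S)[C@@H](NC(=O)c2n[nH]c(Cc3ccccc3)n2)COc2ncccc21`: in this assay compound 3 gives > 10000 nM, also a limit of the assay.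

Compound 2 differs from compound 1 by methyl in place of hydrogen on an aromatic carbon. The step that the two limits leave unreadable from compound 1 to compound 2, since both ends of it are limits; all that can be said is where the values stand (the limit of > 10000 nM in this assay, at which 3 of the 3 values shown sit).

Compound 3 is built on a different core from compound 1; the difference between the two cores is not broken down here.

Compound 4, `Cc1ccc2c(n1)OC[C@H](NC(=O)c1n[nH]c(Cc3ccccc3)n1)C(=S)N2C`, has not yet been measured in this assay. It differs from compound 3 by methyl in place of hydrogen on an aromatic carbon. This is the same kind of change as from compound 1 to compound 2, not the same change: in compound 2 the methyl stands two atoms from the ring nitrogen, in compound 4 it stands next to the ring nitrogen.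

For compound 4 the expectation rests on compound 3, whose value > 10000 nM is only a limit. It rests further on the step that the two limits leave unreadable from compound 1 to compound 2, which no measurement makes readable. Going by the values given here, nothing among the measured compounds shows a methyl of this kind moving a value off the limit, so the step from compound 3 to compound 4 is expected to be a step that the limit leaves unreadable from compound 3 to compound 4. Compound 4 is accordingly estimated at 20000 nM, expected to fall between 7000 nM and 60000 nM, most likely again reported only as a limit.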

Compound 4, half-maximal effective concentration: 122 nM
Estimate against measurement, compound 4: 160-fold (2.21 log units) above, and the stated range ends above it.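

On the core of compound 3, methyl in place of hydrogen on an aromatic carbon, next to the ring nitrogen, gives an at least 81-fold lower number from compound 3 to compound 4 (1.91 log units; beyond the scatter) in this assay, so on this core a single added methyl is enough for a large step. Going by these compounds alone, this does not show that the gain carries over from one core to another: the only other step of this kind, from compound 1 to compound 2, cannot be read, since both of its ends are limits of the assay, and its methyl stands at a different place on the ring. The series therefore gives no measured case of this change working or failing on the core of compound 1, and the readable part of the comparison stays thin: the limit of > 10000 nM in this assay, at which 3 of the 4 values shown sit.

The compounds shown leave open whether a methyl next to the ring nitrogen on the core of compound 1 would also move the value off the limit, so the roles of core and place cannot yet be separated. They also leave open whether the step depends on methyl itself, or whether a longer chain such as ethyl, or an amine, at the same place would give a comparable value.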